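This account rests on a few compounds, and the source may have more. Where it says the series, first, only, none or still open, it means among the compounds named here.

Working notes on the series. Compound 1 `CN(C)c1ccc(Nc2nccc(-c3ccccn3)n2)cc1` is the reference point. In a functional assay for inhibition, with Homo sapiens as the target (on this read-out higher numbers stand for weaker inhibition and lower numbers for stronger inhibition), compound 1 gives 3300 nM, the highest of the three numbers in hand. Compound 2 `Cc1ccsc1-c1ccnc(Nc2ccc(N(C)C)cc2)n1` gives 1800 nM, and compound 3 `CN(C)c1ccc(Nc2nccc(-c3cccs3)n2)cc1` gives 900 nM. Going by the values given here, all the measured steps change the aromatic group attached to the shared core: a 1.8-fold lower number from compound 1 to compound 2 (0.26 log units; within the scatter), a 3.7-fold lower number from compound 1 to compound 3 (0.56 log units; beyond the scatter) and a 2.0-fold lower number from compound 2 to compound 3 (0.30 log units; within the scatter). Among the compounds with values here, only the step from compound 1 to compound 3 lies beyond the scatter, and it is modest.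

Compound 4 `CCc1ccc(Nc2nccc(-c3ccccn3)n2)cc1` differs from compound 1 elsewhere: ethyl in place of dimethylamino on an aromatic carbon. Within the data shown here, none of the measured steps touches this part of the molecule; the dimethylamino group is held constant in compounds 1, 2 and 3, so no measured step bears on the change. The expectation therefore rests only on the scale of the steps seen so far, which ranged from within the scatter to modest, and no direction can be drawn from them for a change at this place. The expected step is a 1.2-fold higher number from compound 1 to compound 4 (0.08 log units; within the scatter), taken as within the scatter, with a wide range to reflect the absence of a precedent. For compound 4 the estimate in this assay is 4000 nM, with a range from 1000 nM to 15000 nM.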

Compound 4, half-maximal inhibitory concentration: 2100 nM
Compound 4: middle estimate off by 1.9-fold (0.28 log units), on the high side, and the stated range covers the measured number.
By their numbers in this assay, from the lowest: compounds 3, 2, 4 and 1 (each within the scatter of the next, the first and the last beyond it).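

Going by these compounds alone, the first change at this place, on an aromatic carbon of a six-membered aromatic ring of carbon only, para to a large group, gives a 1.6-fold lower number from compound 1 to compound 4 (0.20 log units; within the scatter) in this assay when ethyl takes the place of dimethylamino. For this one pair, the read-out therefore stays within the scatter although the substituent goes from 3 heavy atoms to 2, loses its nitrogen and goes from 1 hydrogen-bond acceptor to 0, so dimethylamino is not shown to be required for a number of this size with pyridin-2-yl on the shared core. No supporting measurement bears on the reason for this outcome, and the step stands here as an observation only.

The compounds shown leave open whether ethyl in place of dimethylamino would read the same way with thiophen-2-yl or 3-methylthiophen-2-yl on the shared core, since this change appears only with pyridin-2-yl. They also leave open how a primary amine, a carboxylic acid or a longer chain such as butyl would read at this place, so a single pair gives neither a trend nor a limit for the position.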